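Replacing a ring substituent with an open chain

This account rests on a few compounds, and the source may have more. Where it says the series, first, only, none or still open, it means among the compounds named here.

In a functional assay on A-375 cells (Homo sapiens) for cytotoxicity, read by MTT assay, with a stated time of 72 h (a higher number here means a weaker inhibitor, a lower number a stronger inhibitor), compound 1 `O=C1c2c[n+]([O-])c3ccccc3c2C(=O)c2c1c1ccccc1n2Cc1cn([C@@H]2C[C@H](O)[C@@H](CO)O2)nn1` gives 20 nM, compound 2 `O=C1c2c[n+]([O-])c3ccccc3c2C(=O)c2c1c1ccccc1n2Cc1cn(CC(O)CO)nn1` gives 440 nM and compound 3 `O=C1c2c[n+]([O-])c3ccccc3c2C(=O)c2c1c1ccccc1n2Cc1cn([C@H]2C[C@H](O)[C@@H](CO)O2)nn1` gives 390 nM. Compound 3 therefore sits level with compound 2 and far from compound 1. Compound 4 `O=C1c2c[n+]([O-])c3ccccc3c2C(=O)c2c1c1ccccc1n2Cc1cn(C[C@@H](O)CO)nn1` carries 2,3-dihydroxypropyl in place of the 4-hydroxy-5-(hydroxymethyl)oxolan-2-yl of compound 3: 2,3-dihydroxypropyl in place of 4-hydroxy-5-(hydroxymethyl)oxolan-2-yl on an aromatic nitrogen. The reverse swap is small in a 1.1-fold lower number from compound 2 to compound 3 (0.05 log units; within the scatter), while the same swap is large in a 22-fold higher number from compound 1 to compound 2 (1.34 log units; beyond the scatter). Configuration alone can also matter, given the fact that compounds 1 and 3 differ only in the configuration as drawn and a 20-fold higher number from compound 1 to compound 3 (1.29 log units; beyond the scatter). The ring of compound 3 matches the case with the small step, so the expected 1.0-fold higher number from compound 3 to compound 4 (0.01 log units; within the scatter) stays within the scatter. Compound 4 is estimated at 400 nM, with an expected range of 140 nM to 1000 nM.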

Compound 4, half-maximal inhibitory concentration: 140 nM
For compound 4 the middle estimate is 2.9-fold (0.46 log units) above the measured one; the measured number falls inside the stated range.
By their numbers in this assay, from the lowest: compound 1; then compound 4; then compounds 3 and 2 (each within the scatter of the next).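

The swap to 2,3-dihydroxypropyl on the aromatic nitrogen has no single effect: its direction depends on which ring configuration it replaces, giving (a 2.8-fold lower number from compound 3 to compound 4 (0.44 log units; beyond the scatter)) but also (a 7.0-fold higher number from compound 1 to compound 4 (0.85 log units; beyond the scatter)). Configuration may matter for the open chain too, since the two chain compounds are separated by (a 3.1-fold lower number from compound 2 to compound 4 (0.50 log units; beyond the scatter)), and the only structural difference is in how that centre is drawn: the fact that one of compounds 2 and 4 is drawn with a defined configuration and the other without, at the place where they differ.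

Still open, from the compounds shown here alone, is how the chain with the opposite defined configuration would compare. So is whether an amine or a carboxylic acid in place of a hydroxyl group, or a longer chain, would keep this level of activity.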